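The compounds below may be only part of what the source reports. "The series", "measured", "known", "first", "only" and "open" are said of these compounds alone.

In an ADME assay on THP-1 cells (Homo sapiens) for cytotoxicity, read by flow cytometry and propidium iodide staining, with a stated time of 72 h (a lower number here means a stronger inhibitor, a higher number a weaker inhibitor), compound 1 `COc1ccccc1-c1oc2ccc(NC(C)=O)cc2c(=O)c1O` gives > 125000 nM, which is a limit and not a number; that is the limit of > 125000 nM in this assay, at which 1 of the 3 values shown sits. Compound 2 `COc1cccc(-c2oc3ccc(NC(C)=O)cc3c(=O)c2O)c1` gives 50000 nM, and compound 3 `CC(=O)Nc1ccc2oc(-c3ccc(F)cc3)c(O)c(=O)c2c1` gives 26000 nM. Compound 4 `COc1ccccc1-c1oc2ccc(N)cc2c(=O)c1O` carries hydrogen in place of acetyl on a nitrogen on an aromatic ring, acetamido to amino (hydrogen in place of acetyl on a nitrogen on an aromatic ring). The measured steps, an at least 2.5-fold lower number from compound 1 to compound 2 (0.39 log units; beyond the scatter), an at least 4.8-fold lower number from compound 1 to compound 3 (0.68 log units; beyond the scatter) and a 1.9-fold lower number from compound 2 to compound 3 (0.28 log units; within the scatter), only exchange the substituted phenyl group and keep the acetamido, so they bear on this change only indirectly. They suggest a modest step at most, towards a lower number. The expected change is an at least 2.0-fold lower number from compound 1 to compound 4 (0.31 log units; beyond the scatter). For compound 4 the estimate is 60000 nM, with an expected range from 15000 nM to 125000 nM.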

Compound 4, half-maximal inhibitory concentration: 102000 nM
For compound 4 the middle estimate is 1.7-fold (0.23 log units) below the measured one; the measured number falls inside the stated range.
By their numbers in this assay, from the lowest: compounds 3 and 2 (each within the scatter of the next); then compound 4. At a limit, above all of these: compound 1.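

In this assay, the change from acetamido to amino gives an at least 1.2-fold lower number from compound 1 to compound 4 (0.08 log units; that floor lies within the scatter), so this position can be read only as a floor, and that floor does not establish a shift beyond the scatter. With amino on this nitrogen, the 2-methoxyphenyl compound now has a number rather than a limit. Compound 1 stands at a limit and not a number, and the true size of the step stays unknown because of it: the limit of > 125000 nM in this assay, at which 1 of the 4 values shown sits.

The compounds shown leave open how a propionyl or methyl group on this nitrogen would read. They also leave open whether amino in place of acetamido acts alike alongside 3-methoxyphenyl or 4-fluorophenyl.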